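Changing the group on nitrogen: from compound 2 to compound 4

This account rests on a few compounds, and the source may have more. Where it says the series, first, only, none or still open, it means among the compounds named here.

- compound 1 `Cc1ccc(-n2cc(C(=O)O)c(=O)c3c(O)c(Cc4cccc(Cl)c4F)ccc32)cc1` gives 194000 nM
- compound 2 `O=C(O)c1cn(-c2ccc(Br)cc2)c2ccc(Cc3cccc(Cl)c3F)c(O)c2c1=O` gives 85000 nM
- compound 3 `O=C(O)c1cn(Cc2ccccc2F)c2ccc(Cc3ccccc3F)c(O)c2c1=O` gives 67100 nM

In an ADME assay on C8166 cells (Homo sapiens) for cytotoxicity, read by MTT assay (on this read-out higher numbers stand for lower toxicity in this test and lower numbers for higher toxicity in this test), compound 2 gives 85000 nM and sits within the usual scatter of compound 3, while the measured step of a 2.3-fold lower number from compound 1 to compound 2 (0.36 log units; beyond the scatter) is modest but beyond the scatter. Compound 4 `O=C(O)c1cn(Cc2ccc(F)c(F)c2)c2ccc(Cc3cccc(Cl)c3F)c(O)c2c1=O` has not been measured yet. It differs from compound 2 by 3,4-difluorobenzyl in place of 4-bromophenyl on an aromatic nitrogen in one place: 3,4-difluorobenzyl in place of 4-bromophenyl on an aromatic nitrogen.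

For the measured compounds named here, only one measured step bears on this, and it concerns bromo in place of methyl on an aromatic carbon, not the group on the nitrogen. Compound 3, at 67100 nM and also carrying a benzyl group on that nitrogen, differs from compound 4 in more than one place, so it is only a loose guide. In this assay a small change is therefore expected: the estimated move is a 1.2-fold lower number from compound 2 to compound 4 (0.08 log units; within the scatter) and should stay within the scatter. The estimate for compound 4 is 70000 nM with an expected range from 30000 nM to 160000 nM as its upper end.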

Compound 4, half-maximal cytotoxic concentration: 71400 nM
For compound 4 the middle estimate is 1.0-fold (0.01 log units) below the measured one, within the range that was stated.
By their numbers in this assay, from the lowest: compounds 3, 4 and 2 (each within the scatter of the next); then compound 1.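

On the group attached to the ring nitrogen, this assay now gives a direct comparison: replacing 4-bromophenyl with 3,4-difluorobenzyl gives a 1.2-fold lower number from compound 2 to compound 4 (0.08 log units; within the scatter) and so does not separate these two compounds. Replacing 4-methylphenyl with the same 3,4-difluorobenzyl gives a 2.7-fold lower number from compound 1 to compound 4 (0.43 log units; beyond the scatter) and is a modest step, so a phenyl group on this nitrogen does not by itself set the number, since the outcome depends on which phenyl group is replaced. No measured evidence here explains either step.

All the nitrogen groups shown contain an aromatic ring, leaving open what a longer alkyl chain or a chain ending in an amine would do at this position. Going by these compounds, the separate contributions of the two fluorines on the benzyl group also remain open.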